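This account rests on a few compounds, and the source may have more. Where it says the series, first, only, none or still open, it means among the compounds named here.

Three compounds have so far been measured in a functional assay on HT-29 cells (Homo sapiens) for cytotoxicity, read by sulforhodamine B assay, with a stated time of 48 h; on this read-out higher numbers stand for weaker inhibition and lower numbers for stronger inhibition:

compound 1, `Cc1ccccc1OS(=O)(=O)c1ccc(NC(=O)NCCCCl)cc1`, with 26000 nM
compound 2, `Cc1ccccc1NS(=O)(=O)c1cccc(NC(=O)NCCCCl)c1`, with 42000 nM
compound 3, `CCNC(=O)Nc1ccc(S(=O)(=O)Oc2ccccc2C)cc1`, with 12000 nM

Compound 3 stands lowest of the three numbers. Among the measured compounds shown here, the only single-change step among them, a 2.2-fold lower number from compound 1 to compound 3 (0.34 log units; beyond the scatter), concerns a saturated chain carbon two bonds along the chain from an amide-type nitrogen. For the measured compounds named here, compound 2 differs from the other two in more than one place, and no single step connects it; its value is simply the highest of the three.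

Compound 4, `CCCc1ccccc1OS(=O)(=O)c1ccc(NC(=O)NCC)cc1`, has not yet been measured. It differs from compound 3 by ethyl in place of hydrogen on a saturated chain carbon bound to an aromatic carbon. Going by the values given here, no measured step touches that part of the molecule: the change from compound 1 to compound 3 sits on the chain carbon near the amide-type nitrogen, not on the chain carbon bound to an aromatic carbon, and compound 2 is not joined to the rest by a single change. There is therefore nothing that points to a direction or to a size in this assay beyond the scatter. The expectation for compound 4 is thus a step that stays within the scatter, no change at the digits printed from compound 3 to compound 4 (within the scatter). On that basis compound 4 is expected to give 12000 nM in this assay, with a range from 4000 nM to 36000 nM.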

Compound 4, half-maximal inhibitory concentration: 2400 nM
Compound 4: the middle estimate sits 5.0-fold (0.70 log units) above what was measured, outside the stated range (below it).
By their numbers in this assay, from the lowest: compound 4; then compound 3; then compounds 1 and 2 (each within the scatter of the next).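

Ethyl in place of hydrogen on a saturated chain carbon bound to an aromatic carbon, the same difference that reads methyl to propyl, gives in this assay a 5.0-fold lower number from compound 3 to compound 4 (0.70 log units; beyond the scatter) and so shows that this part of the molecule bears on the number, which the one earlier step, placed on the chain carbon near the amide-type nitrogen, could not show. The direction is towards stronger inhibition, and the added carbon chain is tolerated here rather than costing activity, though this rests on a single pair and makes no pattern beyond compound 3 and compound 4. Nothing in the available evidence accounts for why this change lowers the number.

The compounds shown leave open whether a longer chain such as butyl, a branched chain such as isopropyl, or an amine or a carboxylic acid at the same place would carry the number further down or reverse it. They also leave open whether the change from methyl to propyl would do the same on the core of compound 1, which keeps the chloromethyl, or on the core of compound 2.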